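This account rests on a few compounds, and the source may have more. Where it says the series, first, only, none or still open, it means among the compounds named here.

Measured compounds in a functional assay on cells (Platelet, Homo sapiens) for inhibition; on this read-out lower numbers stand for stronger inhibition and higher numbers for weaker inhibition:
- compound 1 `CCOC(=O)c1ccc(-c2nn(Cc3ccccc3Cl)c3ccccc23)cc1` gives 230 nM
- compound 2 `CCOC(=O)c1ccc(-c2nn(Cc3ccc(Cl)cc3)c3ccccc23)cc1` gives 120 nM
- compound 3 `CCOC(=O)c1ccc(-c2nn(Cc3ccccn3)c3ccccc23)cc1` gives 290 nM

Among the measured compounds shown here, compound 3 stands at the highest of the three numbers; its gap to compound 1 is within the scatter, and only the step of a 2.4-fold higher number from compound 2 to compound 3 (0.38 log units; beyond the scatter) is beyond it, and modest. Compound 4 `CCOC(=O)c1ccc(-c2nn(-c3ccccc3)c3ccccc23)cc1` differs from compound 3 by phenyl in place of (pyridin-2-yl)methyl on an aromatic nitrogen. For the measured compounds named here, the measured steps, a 1.9-fold lower number from compound 1 to compound 2 (0.28 log units; within the scatter) and a 1.3-fold higher number from compound 1 to compound 3 (0.10 log units; within the scatter), exchange only the aryl group on the saturated chain carbon; none removes that carbon or sets an aryl group directly on the aromatic nitrogen, so no step bears directly on this change. Given how narrow the spread across compounds 1 to 3 is, no step beyond the scatter is expected in this assay, with wide uncertainty. Compound 4 is therefore estimated at 250 nM (range 80 nM to 800 nM), an expected step of a 1.2-fold lower number from compound 3 to compound 4 (0.06 log units; within the scatter).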

Compound 4, half-maximal inhibitory concentration: 2640 nM
The estimate for compound 4 lay 11-fold (1.02 log units) below the measured number; the measured number lies above the stated range.
By their numbers in this assay, from the lowest: compounds 2, 1 and 3 (each within the scatter of the next, the first and the last beyond it); then compound 4.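

In this assay the group on the aromatic nitrogen matters more than the earlier aryl exchanges suggested: phenyl gives a 9.1-fold higher number from compound 3 to compound 4 (0.96 log units; beyond the scatter) and an 11-fold higher number from compound 1 to compound 4 (1.06 log units; beyond the scatter) and a 22-fold higher number from compound 2 to compound 4 (1.34 log units; beyond the scatter) as clear losses of inhibition. Each step removes the saturated chain carbon but also changes the aryl group, so the two changes cannot be separated here. No supporting data explain the loss.

From the compounds shown here alone, whether an unsubstituted benzyl group or a longer chain such as 2-phenylethyl on that nitrogen would retain inhibition remains open. Going by these compounds, the effect of a carboxylic acid in place of the ethyl ester is also open.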